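The compounds below may be only part of what the source reports. "The series", "measured", "known", "first", "only" and "open" are said of these compounds alone.

Compound 1 `Cc1cc(C)c(S(=O)(=O)NC2=NCCN2C(=S)SN2CCn3c2nsc3=S)c(C)c1` was tested in a functional assay on KYSE-510 cells (Homo sapiens) for antiproliferative activity, read by crystal violet staining, with a stated time of 96 h; on this read-out higher numbers stand for weaker inhibition of growth and lower numbers for stronger inhibition of growth. In this assay compound 1 gives >= 20000 nM, which is a limit of the assay rather than a number. Two related compounds share its core and differ from it only in the group on the sulfonyl sulfur. Compound 2 `O=S(=O)(NC1=NCCN1C(=S)SN1CCn2c1nsc2=S)c1ccc(Br)cc1` carries a 4-bromophenyl there, and in this assay compound 2 gives >= 20000 nM, again a limit. Compound 3 `O=S(=O)(NC1=NCCN1C(=S)SN1CCn2c1nsc2=S)c1cccc(Cl)c1` carries a 3-chlorophenyl, and in this assay compound 3 gives >= 20000 nM, also a limit. The steps a step that the two limits leave unreadable from compound 1 to compound 2, a step that the two limits leave unreadable from compound 1 to compound 3 and a step that the two limits leave unreadable from compound 2 to compound 3 therefore cannot be sized; all that is known is the limit of >= 20000 nM in this assay, at which 3 of the 3 values shown sit. Compound 4 `O=S(=O)(NC1=NCCN1C(=S)SN1CCn2c1nsc2=S)c1ccc(Cl)c(Cl)c1` is not yet measured. It differs from compound 1 by 3,4-dichlorophenyl in place of 2,4,6-trimethylphenyl on a sulfonyl sulfur. The measured steps that bear on this change are those just named, and none of them gives a readable size or direction. Because the limit of >= 20000 nM in this assay, at which 3 of the 3 values shown sit, holds for every measured compound, no shift beyond the scatter is expected for compound 4, and the most likely outcome is another limit. Compound 4 is estimated at 20000 nM, with a range from 10000 nM to 40000 nM. The expected step of a number no higher from compound 1 to compound 4 (the limit leaves the size open) is thus essentially none.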

Compound 4, concentration for 50% growth inhibition: >= 20000 nM
Compound 4 was reported as a limit; the forecaster's own chance of this, stated with the estimate: 85%; the middle value lies on the limit itself.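

Compound 4 is also reported only as a limit, so its steps from compound 1, compound 2 and compound 3 cannot be read: the limit of >= 20000 nM in this assay, at which 4 of the 4 values shown sit. The compounds shown leave open whether any group on the sulfonyl sulfur changes the result in this assay.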